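The compounds below may be only part of what the source reports. "The series", "measured", "known", "first", "only" and "open" are said of these compounds alone.

Of the compounds shown here, two of a shared core have been measured in a functional assay on MDA-MB-231 cells (Homo sapiens) for antiproliferative activity, read by MTT assay, with a stated time of 48 h; on this read-out lower numbers stand for stronger inhibition and higher numbers for weaker inhibition. Compound 1, `Cc1ccc2nc(Nc3nc(Nc4ccc(S(N)(=O)=O)cc4)ncc3C)sc2c1`, carries a sulfamoyl group on one of its outer rings and a methyl on the other; in this assay compound 1 gives 9080 nM. Compound 2, `Cc1cnc(Nc2ccc([N+](=O)[O-])cc2)nc1Nc1nc2ccccc2s1`, carries a nitro group in the corresponding place and no methyl on the far ring; in this assay compound 2 gives 22500 nM. Compound 2 thus stands at the higher of the two numbers, and the gap to compound 1 lies beyond the usual scatter of the method.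

Compound 3, `Cc1cnc(Nc2ccc(S(N)(=O)=O)cc2)nc1Nc1nc2ccccc2s1`, is obtained from compound 2 by a single change: sulfamoyl in place of nitro on an aromatic carbon. Among the compounds with values here, no measured pair separates this change from the methyl difference, so the expectation rests on what compound 1 and compound 2 show. Since compound 1, which carries the same sulfamoyl group, gives 9080 nM in this assay, compound 3 is expected to fall near that mark, and the step of a 2.3-fold lower number from compound 2 to compound 3 (0.35 log units; beyond the scatter) is expected to lie toward lower numbers, probably beyond the scatter. The estimate for compound 3 in this assay is 10000 nM, with a likely range from 4000 nM to 25000 nM.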

Compound 3, half-maximal inhibitory concentration: 16800 nM
Beside the measured number, compound 3's estimate is 1.7-fold (0.23 log units) below it; measured number inside the range.
By their numbers in this assay, from the lowest: compounds 1, 3 and 2 (each within the scatter of the next, the first and the last beyond it).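

Within the data shown here, compound 3 gives the first single-change steps in this set, so the two differences between compound 1 and compound 2 can now be read apart. In this assay the place para to a large group tolerates sulfamoyl in place of nitro with a 1.3-fold lower number from compound 2 to compound 3 (0.13 log units; within the scatter) as the result, so the hydrogen-bond donor that enters with sulfamoyl brings no difference that can be told from the scatter. Hydrogen in place of methyl on an aromatic carbon gives a 1.9-fold higher number from compound 1 to compound 3 (0.27 log units; within the scatter) as its step, so this change likewise stays inside the scatter when taken alone. Nothing at hand offers an explanation for either step.

Whether any group at the para place can move the number beyond the scatter remains open, since nitro and sulfamoyl are the only two shown there and an amine or a carboxylic acid might behave differently. Going by these compounds, it is equally open whether a longer chain or a chlorine in place of the methyl would change the number, and whether the two single changes would hold their size on a different core.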